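Working notes: from compound 1 to compound 4

The source may hold more compounds than are shown below. What is called first, only, known or untested is meant among the compounds shown, and "the series" means these compounds.

For the measured compounds named here, compound 1 `CCOC(=O)c1c(CSc2ccc(OC)cc2)n(C)c2ccc(O)cc12` carries 4-methoxyphenyl on the sulfur, and in an assay on cells for inhibition of Polyunsaturated fatty acid 5-lipoxygenase (Homo sapiens), read by HPLC, with a stated time of 15 min (on this read-out lower numbers stand for stronger inhibition and higher numbers for weaker inhibition), compound 1 gives 3100 nM, the highest of the three numbers measured so far. Compound 2 `CCOC(=O)c1c(CSc2ccc(OC(F)(F)F)cc2)n(C)c2ccc(O)cc12` gives 2100 nM in this assay; the step of a 1.5-fold lower number from compound 1 to compound 2 (0.17 log units; within the scatter) lies within the scatter. Going by the values given here, compound 3 `CCOC(=O)c1c(CSc2ccccc2C(F)(F)F)n(C)c2ccc(O)cc12` gives 1200 nM in this assay; set against compound 1 the two values differ beyond the scatter, but no single-place step links these two compounds.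

Compound 4 `CCOC(=O)c1c(CSc2c(C)cccc2C)n(C)c2ccc(O)cc12` is not yet measured. It differs from compound 1 by 2,6-dimethylphenyl in place of 4-methoxyphenyl on a sulfur. Among the compounds with values here, the only single-place step in hand, from compound 1 to compound 2, alters a group on an oxygen of that ring and is within the scatter, so it bears only loosely on a change that replaces the whole ring with 2,6-dimethylphenyl. Compound 3 shows that a ring without the methoxy can sit at a lower number than compound 1, but that pair is not a single-place step. On this thin basis a modest move to a lower number is expected for compound 4, amounting to a 1.7-fold lower number from compound 1 to compound 4 (0.24 log units; within the scatter). For compound 4 the estimate in this assay is 1800 nM, within a range from 700 nM to 4500 nM.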

Compound 4, half-maximal inhibitory concentration: 1200 nM
For compound 4 the middle estimate is 1.5-fold (0.18 log units) above the measured one; the measured number falls inside the stated range.
By their numbers in this assay, from the lowest: compounds 3, 4, 2 and 1 (each within the scatter of the next, the first and the last beyond it).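

For the compounds shown here, on the sulfur, 2,6-dimethylphenyl in place of 4-methoxyphenyl gives the first single-place step in this assay that lies beyond the scatter (a 2.6-fold lower number from compound 1 to compound 4 (0.41 log units; beyond the scatter)), whereas the earlier step, which altered only the group on the oxygen of that ring, stayed within it (a 1.5-fold lower number from compound 1 to compound 2 (0.17 log units; within the scatter)). The whole ring at this position can therefore be exchanged without a rise in the number, and the hydrogen-bond acceptor counted in 4-methoxyphenyl is not needed for a value at this level, since 2,6-dimethylphenyl has none. This one step removes the methoxy and adds both methyl groups at once, so it does not separate their contributions, and nothing at hand gives a reason for the shift.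

Open, as far as these compounds go, is whether a single methyl on the ring would match 2,6-dimethylphenyl, and how an unsubstituted phenyl, a chlorophenyl or a saturated cyclohexyl on the sulfur would read. The ethyl ester and the hydroxyl on the shared core are constant across all four compounds, so a carboxylic acid or an amide in place of that ester remains an untested question for this series.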